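The source may hold more compounds than are shown below. What is called first, only, known or untested is meant among the compounds shown, and "the series" means these compounds.

Among the compounds with values here, in an ADME assay on microsomes from liver (Homo sapiens) for metabolic stability, using NADPH, with a stated time of 40 min, tested at 2 uM (a higher number here means that the compound lasts longer, a lower number that the compound disappears faster), compound 1 `Fc1cc2c(-c3ccc4c(C(F)(F)F)cccc4n3)c[nH]c2c(F)c1F` gives 1.12 h and compound 2 `CC(C)NC(=O)c1cccc2nc(-c3c[nH]c4c(F)c(F)c(F)cc34)ccc12` gives 3.43 h, the higher of the two numbers so far. Compound 3 `Fc1cc2c(-c3ccc4ccccc4n3)c[nH]c2c(F)c1F` has not yet been measured. It differs from compound 2 by hydrogen in place of isopropylcarbamoyl on an aromatic carbon, which puts hydrogen in place of isopropylcarbamoyl on an aromatic carbon. Within the data shown here, only one measured step bears on this carbon: a 3.1-fold higher number from compound 1 to compound 2 (0.49 log units; beyond the scatter), a modest change beyond the scatter, with isopropylcarbamoyl in place of trifluoromethyl. Among the measured compounds shown here, no measured compound carries hydrogen there, so the effect of that swap has not been seen directly, and the reasoning rests on this single step. For the measured compounds named here, since isopropylcarbamoyl is the one group so far tied to the higher number, its loss is expected to take the value back towards that of compound 1, at 1.12 h. The expected change is a 2.9-fold lower number from compound 2 to compound 3 (0.46 log units; beyond the scatter), a fall beyond the scatter and similar in size to the earlier rise. For compound 3 the estimated half-life is 1.2 h, with an expected range from 0.5 h to 2.8 h.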

Compound 3, half-life: 0.25 h
The estimate for compound 3 lay 4.8-fold (0.68 log units) above the measured number; the measured number lies below the stated range.
By their numbers in this assay, from the lowest: compound 3; then compound 1; then compound 2.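

Hydrogen on this aromatic carbon proves to be the lowest of the three groups seen so far in this assay: the loss of isopropylcarbamoyl gives a 14-fold lower number from compound 2 to compound 3 (1.14 log units; beyond the scatter), a large step, where the rise first seen with this group was modest. Trifluoromethyl also stands above hydrogen, with a 4.5-fold lower number from compound 1 to compound 3 (0.65 log units; beyond the scatter), so the earlier comparison of two substituents had hidden the fact that, on this core, both give a longer half-life than hydrogen, and that the three compounds form a clear order of hydrogen, then trifluoromethyl, then isopropylcarbamoyl. Nothing given here accounts for this order or explains why either group differs from hydrogen.

The compounds shown leave open where other groups on this carbon would fall in that order, such as a carboxylic acid, an amine or a methyl ester. They also leave open whether the amide itself or its isopropyl part goes with the highest number, which a primary carboxamide or an amide with a longer chain would help to separate.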